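Chain-length and ring variants on a sulfonyl-linked catechol series

The source may hold more compounds than are shown below. What is called first, only, known or untested is meant among the compounds shown, and "the series" means these compounds.

Three analogues share a core and differ only at the saturated chain carbon bound to the sulfonyl sulfur. In a functional assay, read by fluorescence and spectrophotometry, with a stated time of 1 h (a lower number here means that less compound is needed, a higher number that more compound is needed for the effect), compound 1 `O=S(=O)(/C=C/c1ccc(O)c(O)c1)CC1CCC1` gives 8800 nM, the second highest of the three numbers. Compound 2 `O=S(=O)(/C=C/c1ccc(O)c(O)c1)CC1CC1` gives 10500 nM, and the step of a 1.2-fold higher number from compound 1 to compound 2 (0.08 log units; within the scatter) is within the scatter. Compound 3 `O=S(=O)(/C=C/c1ccc(O)c(O)c1)CCCCCCCCO` gives 6700 nM, again within the scatter of compound 1.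

Compound 4 `O=S(=O)(/C=C/c1ccc(O)c(O)c1)CCCCCCCO` is not yet measured. It differs from compound 1 by 6-hydroxyhexyl in place of cyclobutyl on a saturated chain carbon bound to a sulfonyl sulfur. For the measured compounds named here, no measured step covers this exact change; the nearest guide is compound 3, whose hydroxyalkyl chain gives a number close to compound 1. A step of a 1.2-fold lower number from compound 1 to compound 4 (0.07 log units; within the scatter) is therefore expected, not beyond the scatter. Compound 4 is estimated at 7500 nM, with a range from 3500 nM to 16000 nM.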

Compound 4, half-maximal effective concentration: 5900 nM
The estimate for compound 4 lay 1.3-fold (0.10 log units) above the measured number; low and high end bracket the measured number.
By their numbers in this assay, from the lowest: compounds 4, 3, 1 and 2 (each within the scatter of the next).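

In this assay, 6-hydroxyhexyl in place of a ring on a saturated chain carbon bound to a sulfonyl sulfur stays within the scatter for both cyclobutyl (a 1.5-fold lower number from compound 1 to compound 4 (0.17 log units; within the scatter)) and cyclopropyl (a 1.8-fold lower number from compound 2 to compound 4 (0.25 log units; within the scatter)). The two hydroxyalkyl compounds also stay within the scatter of each other (a 1.1-fold lower number from compound 3 to compound 4 (0.06 log units; within the scatter)), so no step among these four compounds separates ring from open chain or one hydroxyalkyl chain from the other. No supporting data bear on why these numbers sit so close.

On these data alone, whether an amine, a carboxylic acid or a much longer chain in place of cyclobutyl would give a step beyond the scatter remains open.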